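The compounds below may be only part of what the source reports. "The series", "measured", "known", "first", "only" and "open" are said of these compounds alone.

Measured so far in a functional assay on HepG2 cells (Homo sapiens) for cytotoxicity, read by MTT assay, with a stated time of 48 h; a higher number here means a weaker inhibitor, a lower number a stronger inhibitor:
- compound 1 `CC(C)=CCC/C(C)=C/CC/C(C)=C/CC[C@@H]1[C@@]2(C)CC/C(=N\OCc3cn(-c4ccccc4)nn3)C(C)(C)[C@@H]2CC[C@@]1(C)O`: 9520 nM
- compound 2 `CC(C)=CCC/C(C)=C/CC/C(C)=C/CC[C@@H]1[C@@]2(C)CC/C(=N\OCc3cn(-c4ccccc4C#N)nn3)C(C)(C)[C@@H]2CC[C@@]1(C)O`: 21900 nM
- compound 3 `CC(C)=CCC/C(C)=C/CC/C(C)=C/CC[C@@H]1[C@@]2(C)C/C(=C\c3ccc(OCc4cn(-c5ccccc5)nn4)cc3)C(=O)C(C)(C)[C@@H]2CC[C@@]1(C)O`: 126000 nM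

Compound 3 gives the highest of the three numbers in this assay; its nearest neighbour is compound 2, and compound 1 lies furthest off, both of them well beyond the scatter from compound 3.

Compound 4 `CC(C)=CCC/C(C)=C/CC/C(C)=C/CC[C@@H]1[C@@]2(C)C/C(=C\c3ccc(OCc4cn(-c5c(Cl)cc([N+](=O)[O-])cc5Cl)nn4)cc3)C(=O)C(C)(C)[C@@H]2CC[C@@]1(C)O` differs from compound 3 by one change, (2,6-dichloro-4-nitrophenyl in place of phenyl on an aromatic nitrogen). For the measured compounds named here, the only measured step that bears on this is the one between compound 1 and compound 2, where a cyano in place of hydrogen on an aromatic carbon gave a 2.3-fold higher number from compound 1 to compound 2 (0.36 log units; beyond the scatter), a modest shift. That step points to a modest rise in the number on substituting the phenyl, so a small increase is expected here, near the edge of the scatter. Compound 4 is accordingly estimated at 180000 nM in this assay, with a range of 70000 nM to 450000 nM, the expected step being a 1.4-fold higher number from compound 3 to compound 4 (0.15 log units; within the scatter).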

Compound 4, half-maximal inhibitory concentration: 25100 nM
The estimate for compound 4 lay 7.2-fold (0.86 log units) above the measured number, outside the stated range (below it).
By their numbers in this assay, from the lowest: compound 1; then compounds 2 and 4 (each within the scatter of the next); then compound 3.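

In this assay, 2,6-dichloro-4-nitrophenyl in place of phenyl on an aromatic nitrogen gives a 5.0-fold lower number from compound 3 to compound 4 (0.70 log units; beyond the scatter) on the core of compound 3. This runs opposite to the cyano change on the core of compound 1, a 2.3-fold higher number from compound 1 to compound 2 (0.36 log units; beyond the scatter), so the two substituted phenyl groups do not move the number in one direction. Nothing available here accounts for the step.

As far as these compounds go, it remains open whether the shift follows the chlorine atoms or the nitro group. Also open, from the compounds shown here alone, are whether an amine in place of the nitro group keeps the lower number and how the 2,6-dichloro-4-nitrophenyl group behaves on the core of compound 1.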